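Swapping the Aniline Substituent in a Sparingly Soluble Series

A few compounds are considered here, and "the series" means these few. Any claim that something is new, unique, unknown or untested is made for them only; others in the source may bear on it.

Compound 1, with the structure `CNC(=O)c1cc(Oc2ccc3nc(Nc4cccc(C(C)(C)C)c4)ncc3c2)ccn1`, is the starting point. In a physicochemical assay for solubility, at pH 7 (a lower number here means a less soluble compound, a higher number a more soluble compound), compound 1 gives < 1000 nM, which is a limit of the measurement rather than a number. Compound 2, with the structure `CNC(=O)c1cc(Oc2ccc3nc(Nc4cccc(C(C)(C)C)c4)ccc3c2)ccn1`, belongs to the same set. In this assay compound 2 gives < 1000 nM, again a limit and not a number. Together these results show only that (the limit of < 1000 nM in this assay, at which 2 of the 2 values shown sit); no measured step between the two can be stated.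

Compound 3, with the structure `CCc1ccccc1Nc1ncc2cc(Oc3ccnc(C(=O)NC)c3)ccc2n1`, has not yet been measured in this assay. It differs from compound 1 in one place: 2-ethylphenyl in place of 3-(tert-butyl)phenyl on a nitrogen on an aromatic ring. For the measured compounds named here, no measured pair shows what such a change does to solubility, so the expectation rests on compound 1 giving < 1000 nM in this assay. The step expected here, an at least 1.5-fold higher number from compound 1 to compound 3 (0.17 log units; that floor lies within the scatter), is small, probably no larger than the usual scatter, and if anything toward higher solubility. Compound 3 is therefore estimated to give 1500 nM in this assay, within a range from 400 nM to 6000 nM, with a real chance that only a limit is again reported.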

Compound 3, solubility: < 1000 nM
Compound 3: a limit, no number (the forecaster's own chance of this, stated with the estimate: 45%); at least 1.5-fold (0.17 log units) between middle value and limit.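

In this assay, compound 3 gives < 1000 nM, again a limit and not a number. No step from compound 1 to compound 3 can be read, because neither result is a number: the limit of < 1000 nM in this assay, at which 3 of the 3 values shown sit.

The compounds shown leave open what the actual solubility of each one is, and whether 2-ethylphenyl in place of 3-(tert-butyl)phenyl changes it at all.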